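Cytotoxicity notes on three measured analogues and one proposed

This account rests on a few compounds, and the source may have more. Where it says the series, first, only, none or still open, it means among the compounds named here.

Measured so far:
compound 1 `Nc1nc(-c2ccc(Br)cc2)cn1/N=C/c1cc2ccccc2nc1Cl` gives 11900 nM
compound 2 `Cc1ccc2nc(Cl)c(/C=N/n3cc(-c4ccccc4)nc3N)cc2c1` gives 41500 nM
compound 3 `COc1ccc(-c2cn(/N=C/c3cc4cc(C)ccc4nc3Cl)c(N)n2)cc1` gives 12200 nM

In an ADME assay on HUVEC cells (Homo sapiens) for cytotoxicity, read by MTT assay, with a stated time of 48 h (a lower number here means a stronger inhibitor, a higher number a weaker inhibitor), compound 3 stands second highest of the three numbers. Its nearest neighbour is compound 1, whose value lies within the scatter of that of compound 3, so no order can be read between the two. Among the measured compounds shown here, its furthest neighbour is compound 2; the one recorded step, a 3.4-fold lower number from compound 2 to compound 3 (0.53 log units; beyond the scatter), separates them and lies beyond the scatter.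

Compound 4 `Cc1ccc2nc(Cl)c(/C=N/n3cc(-c4ccc(Br)cc4)nc3N)cc2c1` is the unmeasured analogue. It differs from compound 3 by bromo in place of methoxy on an aromatic carbon. For the measured compounds named here, no measured step describes a bromo in place of a methoxy on its own: compound 1 also carries a bromo on the same ring, but it differs from compound 3 in the shared core as well, so only the two values can be compared, and they agree within the scatter. The step from compound 2 to compound 3 concerns a different exchange and does not bear directly on this one.

With compound 1 and compound 3 agreeing, the expectation for compound 4 in this assay is a value near that of compound 3, a step of a 1.1-fold higher number from compound 3 to compound 4 (0.06 log units; within the scatter), not beyond the scatter. Compound 4 is therefore estimated at 14000 nM, with a range from 6500 nM to 32000 nM.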

Compound 4, half-maximal inhibitory concentration: 13400 nM
Compound 4: middle estimate off by 1.0-fold (0.02 log units), on the high side; low and high end bracket the measured number.
By their numbers in this assay, from the lowest: compounds 1, 3 and 4 (each within the scatter of the next); then compound 2.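

In this assay, the change from 4-methoxyphenyl to 4-bromophenyl now has a measured step of its own, a 1.1-fold higher number from compound 3 to compound 4 (0.04 log units; within the scatter), so bromo and methoxy on this aromatic carbon, para to a large group, cannot be told apart, which the earlier comparison across compounds differing in more than one place could not show. Bromo in place of hydrogen at this position gives a 3.1-fold lower number from compound 2 to compound 4 (0.49 log units; beyond the scatter), and methoxy in place of hydrogen gives a 3.4-fold lower number from compound 2 to compound 3 (0.53 log units; beyond the scatter), so both substituted compounds stand apart from the unsubstituted phenyl but not from each other. Methyl in place of hydrogen on an aromatic carbon of the shared core, a different place, gives a 1.1-fold higher number from compound 1 to compound 4 (0.05 log units; within the scatter), so with the bromo held fixed, that methyl makes no readable difference.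

Nothing shown here accounts for these steps. From the compounds shown here alone, whether an amine, a carboxylic acid or a longer chain such as ethoxy at this position would stay with compound 3 and compound 4 or return to the number of compound 2 remains open, as does whether the methyl would make as little difference alongside methoxy.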